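A few compounds are considered here, and "the series" means these few. Any claim that something is new, unique, unknown or untested is made for them only; others in the source may bear on it.

Three compounds share one core and differ only in the chain that hangs from a saturated ring carbon. Compound 1 `Cn1ncc(Cl)c1-c1cc(C(=O)N[C@@H]2CN[C@H](CC(O)CO)C[C@H]2c2ccc(F)c(F)c2)oc1Cl` gives 690 nM in a functional assay on OVCAR-8 cells (Homo sapiens) for antiproliferative activity; on this read-out lower numbers stand for stronger inhibition and higher numbers for weaker inhibition. Compound 2 `Cn1ncc(Cl)c1-c1cc(C(=O)N[C@@H]2CN[C@H](CCCO)C[C@H]2c2ccc(Cl)c(Cl)c2)oc1Cl` gives 600 nM in this assay, and compound 3 `CC(=O)NCC[C@@H]1C[C@@H](c2ccc(F)c(F)c2)[C@H](NC(=O)c2cc(-c3c(Cl)cnn3C)c(Cl)o2)CN1` gives 880 nM. The three numbers sit within the scatter of one another, so on these data compound 2 is neither set apart from compound 1 nor from compound 3.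

Compound 4 `Cn1ncc(Cl)c1-c1cc(C(=O)N[C@@H]2CN[C@H](CC(=O)NC3CCC3)C[C@H]2c2ccc(Cl)c(Cl)c2)oc1Cl` has not yet been measured. From compound 2 it differs in one place: cyclobutylcarbamoyl in place of 2-hydroxyethyl on a saturated chain carbon bound to a saturated ring carbon. Within the data shown here, the only measured step that touches the same chain position is a 1.3-fold higher number from compound 1 to compound 3 (0.11 log units; within the scatter), where exchanging one chain end for an amide-bearing one left the number within the scatter. The change to compound 4 is of the same kind, an amide entering at the chain end, so the expectation is a step no larger than the scatter, a 1.2-fold higher number from compound 2 to compound 4 (0.07 log units; within the scatter). Compound 4 is therefore estimated at 700 nM, with a range from 300 nM to 1600 nM.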

Compound 4, half-maximal inhibitory concentration: 610 nM
Compound 4: the middle estimate sits 1.1-fold (0.06 log units) above what was measured; the measured number falls inside the stated range.
By their numbers in this assay, from the lowest: compounds 2, 4, 1 and 3 (each within the scatter of the next).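

In this assay, cyclobutylcarbamoyl in place of 2-hydroxyethyl gives a 1.0-fold higher number from compound 2 to compound 4 (0.01 log units; within the scatter), so this change on a saturated chain carbon bound to a saturated ring carbon leaves the number within the scatter. The earlier chains carried no ring, whereas the entering group brings a four-membered non-aromatic ring of carbon only and more heavy atoms, and this position still tolerates that change in this assay. Nothing available explains why the number stays within the scatter. All four chains give numbers within the scatter of the next, so the compounds shown do not reveal any chain end that sets a compound apart. On these data alone, it remains open whether a primary amine, a carboxylic acid or a larger ring such as cyclohexyl at the chain end would do so.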